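A Hydroxyphenyl Replaces Nitrophenyl in a Lipophilicity Series

The source may hold more compounds than are shown below. What is called first, only, known or untested is meant among the compounds shown, and "the series" means these compounds.

Of the compounds shown here, three sharing one core have been measured in a physicochemical assay for lipophilicity, measured as octanol-water partition; on this read-out higher numbers stand for higher lipophilicity and lower numbers for lower lipophilicity. Compound 1 `COc1ccc(C2C(C(=O)OCc3ccccn3)=C(C)NC3=C2C(=O)CCC3)cc1` gives 1.9, compound 2 `CC1=C(C(=O)OCc2ccccn2)C(c2ccc([N+](=O)[O-])cc2)C2=C(CCCC2=O)N1` gives 1.88, and compound 3 `CC1=C(C(=O)OCc2cccnc2)C(c2ccc([N+](=O)[O-])cc2)C2=C(CCCC2=O)N1` gives 1.51. Compound 2 stands second highest of the three numbers: its nearest neighbour is compound 1, and the two differ only within the scatter, while compound 3 lies further off, beyond the scatter. The two measured steps are a number 0.02 log units lower from compound 1 to compound 2 (within the scatter) and a number 0.37 log units lower from compound 2 to compound 3 (beyond the scatter).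

Compound 4 `CC1=C(C(=O)OCc2ccccn2)C(c2cccc(O)c2)C2=C(CCCC2=O)N1` is not yet measured in this assay. It differs from compound 2 in one place: 3-hydroxyphenyl in place of 4-nitrophenyl on a saturated ring carbon. Within the data shown here, only the step from compound 1 to compound 2 bears on this change, since it also alters the group on the same saturated ring carbon; that step was within the scatter. Among the measured compounds shown here, no measured step introduces a hydroxyl group, so the effect of the hydrogen-bond donor that enters is not known from these data.

A modest fall is therefore expected, with the estimated step being a number 0.33 log units lower from compound 2 to compound 4 (beyond the scatter). Compound 4 is expected to give about 1.55 in this assay, within a range from 1.2 to 1.9.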

Compound 4, partition coefficient: 1.58
Compound 4: the middle estimate sits 0.03 log units below what was measured, within the range that was stated.
By their numbers in this assay, from the lowest: compounds 3, 4, 2 and 1 (each within the scatter of the next, the first and the last beyond it).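

In this assay, placing 3-hydroxyphenyl on the saturated ring carbon gives a number 0.30 log units lower from compound 2 to compound 4 (within the scatter) when it replaces 4-nitrophenyl, and a number 0.32 log units lower from compound 1 to compound 4 (beyond the scatter) when it replaces 4-methoxyphenyl. Among these compounds, the earlier exchange at this carbon, between 4-methoxyphenyl and 4-nitrophenyl, stayed within the scatter, so compound 4 provides the first step at this position that lies beyond it, and 3-hydroxyphenyl is also the first group here to carry a hydrogen-bond donor. Nothing available explains why the read-out behaves this way.

The compounds shown leave open whether the step beyond the scatter belongs to the hydroxyl group itself or to its place on the aromatic ring, since the two change together in compound 4. A 4-hydroxyphenyl or 3-methoxyphenyl group on the same saturated ring carbon would separate those two changes, and an aminophenyl group or a carboxylic acid on the aromatic ring would show how far the read-out moves with other groups at this position.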